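The source may hold more compounds than are shown below. What is called first, only, known or untested is meant among the compounds shown, and "the series" means these compounds.

Measured so far:
compound 1, `CC(=O)NN=C1C(Cl)=C(Cl)C(Cl)=C1Cl`: in a functional assay on RPMI-8226 cells (Homo sapiens) for cytotoxicity, read by MTT assay, with a stated time of 48 h (a higher number here means a weaker inhibitor, a lower number a stronger inhibitor), compound 1 gives 1000 nM
compound 2, `C#CC(C)(C)OC(=O)NN=C1C(Cl)=C(Cl)C(Cl)=C1Cl`: in this assay compound 2 gives > 5000 nM, which is a limit of the assay and not a number
compound 3, `CC(C)(C)OC(=O)NN=C1C(Cl)=C(Cl)C(Cl)=C1Cl`: in this assay compound 3 gives 100 nM

Compound 3 has the lowest of the two numbers measured, and its nearest neighbour is a full step away: a 10-fold lower number from compound 1 to compound 3 (1.00 log units; beyond the scatter). Compound 4, `C#CCOC(=O)NN=C1C(Cl)=C(Cl)C(Cl)=C1Cl`, has not been measured. It differs from compound 3 as follows: propargyl in place of tert-butyl on an oxygen next to a carbonyl group. Going by the values given here, two measured steps bear on this. Within the carbamates, an at least 50-fold lower number from compound 2 to compound 3 (1.69 log units; beyond the scatter); the ethynyl-bearing compound 2 reached only (the limit of > 5000 nM in this assay, at which 1 of the 3 values shown sits). Also an at least 5.0-fold higher number from compound 1 to compound 2 (0.69 log units; beyond the scatter). Compound 4 brings a triple bond into the same region, so a weakening of compound 3 is expected in this assay, though compound 4 lacks the two methyls of compound 2, leaving the size uncertain. For compound 4 the expected step is a 20-fold higher number from compound 3 to compound 4 (1.30 log units; beyond the scatter). The estimate for compound 4 is 2000 nM, with a range from 300 nM to 10000 nM.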

Compound 4, half-maximal inhibitory concentration: 800 nM
Beside the measured number, compound 4's estimate is 2.5-fold (0.40 log units) above it, within the range that was stated.
By their numbers in this assay, from the lowest: compound 3; then compounds 4 and 1 (each within the scatter of the next). At a limit, above all of these: compound 2.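

In this assay, a triple bond on this oxygen does not by itself place a compound at the weak end: propargyl in place of 1,1-dimethylprop-2-yn-1-yl gives an at least 6.2-fold lower number from compound 2 to compound 4 (0.79 log units; beyond the scatter), although tert-butyl remains the better group of the two here, with an 8.0-fold higher number from compound 3 to compound 4 (0.90 log units; beyond the scatter). The value of compound 2 is a limit and not a number: the limit of > 5000 nM in this assay, at which 1 of the 4 values shown sits. Swapping the methyl on the carbonyl carbon for propargyloxy brings no change that can be told apart from scatter, with a 1.3-fold lower number from compound 1 to compound 4 (0.10 log units; within the scatter).

As far as these compounds go, the three groups on this oxygen vary branching and the triple bond together, so the share of each in these steps stays open. A propyl chain, a saturated match for propargyl, would help to separate them, and an isopropyl group would show how much branching alone contributes.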